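Swapping an anilide for a thiazolylamide in a cinnamate series

The source may report more compounds than this note shows. Statements on the series, on what has been measured and on what is new or still open speak of the compounds shown alone.

Compound 2 `COCOc1cc(/C=C/C(=O)OCC(=O)Nc2ccc(Cl)cc2)ccc1OCc1ccccc1` is the point of departure. In a functional assay on CNE cells (Homo sapiens) for cytotoxicity, read by MTT assay, with a stated time of 72 h (a lower number here means a stronger inhibitor, a higher number a weaker inhibitor), compound 2 gives only a limit, > 200000 nM, and not a number. Compound 1 `COCOc1cc(/C=C/C(=O)OCC(=O)Nc2ccc(OC)cc2)ccc1OCc1ccccc1` differs from it by a methoxy in place of the chloro on the aromatic carbon; in this assay compound 1 likewise gives only a limit, > 200000 nM. The step from one to the other, a step that the two limits leave unreadable from compound 1 to compound 2, therefore cannot be read. Compound 3 `COCOc1ccc(/C=C/C(=O)N2CCN(Cc3ccc(Cl)c(Cl)c3)CC2)cc1OCOC`, built on a different amide, also gives in this assay only a limit, > 200000 nM. All of the measured values thus sit at the same point, (the limit of > 200000 nM in this assay, at which 3 of the 3 values shown sit), so compound 2 stands neither above nor below any companion on what has been measured.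

Compound 4 `COCOc1cc(/C=C/C(=O)OCC(=O)Nc2nccs2)ccc1OCc1ccccc1` carries the change (1,3-thiazol-2-yl in place of 4-chlorophenyl on an amide-type nitrogen). Among the compounds with values here, no measured step bears on this change, since the only step between measured compounds is unreadable and nothing is known about a thiazolyl amide. With every measured value resting at a limit, compound 4 is expected to stay there as well, so that the step that the limit leaves unreadable from compound 2 to compound 4 is expected to be no more than the scatter. Compound 4 is estimated at 300000 nM in this assay, within a range from 100000 nM to 1000000 nM.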

Compound 4, half-maximal inhibitory concentration: > 200000 nM
Compound 4 was reported as a limit; the forecaster's own chance of this, stated with the estimate: 85%; the middle value is on the limit's open side.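

In this assay compound 4 gives > 200000 nM, a limit and not a number. Its steps from compound 1 and from compound 2 cannot be read, and all values shown now sit together: the limit of > 200000 nM in this assay, at which 4 of the 4 values shown sit.

The compounds shown leave open whether 1,3-thiazol-2-yl, 4-chlorophenyl and 4-methoxyphenyl on this amide-type nitrogen differ at all in cytotoxicity.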